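The source may report more compounds than this note shows. Statements on the series, on what has been measured and on what is new or still open speak of the compounds shown alone.

Measured in a functional assay on MCF7 cells (Homo sapiens) for antiproliferative activity, read by MTT assay, with a stated time of 48 h; on this read-out lower numbers stand for stronger inhibition and higher numbers for weaker inhibition:
- compound 1 `COc1ccc(C(=O)c2ccc(OC)c3c2OC(C)(C)C=C3)c(NC(=O)CBr)c1`: 2360 nM
- compound 2 `COc1ccc(C(=O)c2ccc3c(c2)C=CC(C)(C)O3)c(NC(=O)CBr)c1`: 2880 nM

Compound 1, at 2360 nM, and compound 2, at 2880 nM, lie within the usual scatter of each other, so neither ranks ahead.

Compound 3 `COc1ccc(C(=O)c2ccc(OC)c3c2OC(C)(C)C=C3)c(NC(=O)CO)c1` carries hydroxy in place of bromo on a saturated chain carbon bound to a carbonyl carbon of compound 1: hydroxy in place of bromo on a saturated chain carbon bound to a carbonyl carbon. For the measured compounds named here, no measured pair shows this swap, so the expectation rests on the structural change alone: a clear step towards weaker inhibition in this assay, beyond the scatter. The expected move is a 5.1-fold higher number from compound 1 to compound 3 (0.71 log units; beyond the scatter). Compound 3 is estimated at 12000 nM, with an expected range of 3500 nM to 45000 nM.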

Compound 3, half-maximal inhibitory concentration: 320 nM
Compound 3: the middle estimate sits 38-fold (1.57 log units) above what was measured, and the stated range ends above it.
By their numbers in this assay, from the lowest: compound 3; then compounds 1 and 2 (each within the scatter of the next).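

Putting hydroxy in place of bromo on this saturated chain carbon bound to a carbonyl carbon gives a 7.4-fold lower number from compound 1 to compound 3 (0.87 log units; beyond the scatter) in this assay. Compounds 1 and 2 both carry bromo here, so they could not show that this position responds to a change, or that bromo is not required for the activity of compound 3. Nothing available gives a reason for this step.

On these data alone, an amine on the same carbon remains open, as does a longer chain carrying the hydroxy. Whether this swap would have the same effect on the core of compound 2 is also unresolved.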